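Bromo to 4-bromophenyl on the shared core

This account rests on a few compounds, and the source may have more. Where it says the series, first, only, none or still open, it means among the compounds named here.

For the measured compounds named here, compound 1 `Brc1cn2ccnc2c(-c2ccc3ncn(C4CCCCC4)c3c2)n1` is one of two compounds measured in a functional assay on 786-0 cells (Homo sapiens) for inhibition, read by sulforhodamine B assay, with a stated time of 48 h, tested at 10 uM; a lower number here means less inhibition, a higher number more inhibition at the concentration tested (going by the name of the read-out). In this assay, going by the values given here, compound 1 gives 10%, while compound 2 `Clc1ccc(-c2cn3ccnc3c(-c3ccc4ncn(C5CCCCC5)c4c3)n2)cc1` gives 12.1%; the two numbers lie within the scatter of each other, so compound 1 stands level with the only neighbour it has. The change from compound 1 to compound 3 `Brc1ccc(-c2cn3ccnc3c(-c3ccc4ncn(C5CCCCC5)c4c3)n2)cc1` is 4-bromophenyl in place of bromo on an aromatic carbon. Among the compounds with values here, one measured step bears on it: the same place on the core, with 4-chlorophenyl in place of bromo, gave a number 2.1 percentage points higher from compound 1 to compound 2 (within the scatter). Since that closely related step stayed within the scatter, compound 3 is expected to move no further than the scatter as well, so the expected step is a number 2 percentage points higher from compound 1 to compound 3 (within the scatter). For compound 3 in this assay the estimated inhibition is 12%, with a range from 2% to 25%.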

Compound 3, a percentage reported as inhibition, at one concentration (the size of the read-out at that concentration, not a potency): 18%
The estimate for compound 3 lay 6 percentage points below the measured number; measured number inside the range.
By their numbers in this assay, from the lowest: compounds 1, 2 and 3 (each within the scatter of the next).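

Placing 4-bromophenyl on this aromatic carbon in place of bromo adds a six-membered aromatic ring of carbon only, yet in this assay the result is a number 8 percentage points higher from compound 1 to compound 3 (within the scatter) and stays unresolved from the starting number. Exchanging the halogen on the added ring, bromo in place of chloro, gives a number 5.9 percentage points higher from compound 2 to compound 3 (within the scatter) and no separation either, so at this concentration neither the added ring nor the choice between these two halogens produces a difference that can be told from the scatter. Nothing measured here offers an explanation for these numbers.

The compounds shown leave open whether a different kind of group at this carbon, such as an amine or a carboxylic acid, would move the number beyond the scatter. As far as these compounds go, all three share the rest of the core, so the effect of changes elsewhere also remains open.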